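Imidazolyl for piperidinyl on the acylguanidine series

The source may report more compounds than this note shows. Statements on the series, on what has been measured and on what is new or still open speak of the compounds shown alone.

Measured compounds in a functional assay for inhibition of sodium/hydrogen exchanger (Oryctolagus cuniculus); on this read-out lower numbers stand for stronger inhibition and higher numbers for weaker inhibition:
compound 1 `Cc1cc(OC2CCCCC2)c(S(C)(=O)=O)cc1C(=O)N=C(N)N` 37 nM
compound 2 `Cc1cc(Oc2ccccc2)c(S(C)(=O)=O)cc1C(=O)N=C(N)N` 10 nM
compound 3 `Cc1cc(N2CCCCC2)c(S(C)(=O)=O)cc1C(=O)N=C(N)N` 21 nM

Compound 3 sits second highest of the three numbers in this assay; its nearest neighbour is compound 1, within the scatter, and its furthest is compound 2, which gives the lowest number. The step of a 2.1-fold higher number from compound 2 to compound 3 (0.32 log units; beyond the scatter) is modest but beyond the scatter.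

Compound 4 `Cc1cn(-c2cc(C)c(C(=O)N=C(N)N)cc2S(C)(=O)=O)cn1` differs from compound 3 as follows: 4-methyl-1H-imidazol-1-yl in place of piperidin-1-yl on an aromatic carbon. A saturated six-membered ring on this aromatic carbon gives way to a five-membered aromatic ring with two hetero atoms.

Within the data shown here, two measured steps bear on this change, both exchanging a saturated ring for an aromatic one at the same position: a 3.7-fold lower number from compound 1 to compound 2 (0.57 log units; beyond the scatter) and, read in reverse, a 2.1-fold higher number from compound 2 to compound 3 (0.32 log units; beyond the scatter). Both place the aromatic ring at a lower number in this assay. The entering ring is smaller and nitrogen-containing, so the carry-over to compound 4 is uncertain, but a modest step to a lower number is expected, a 1.8-fold lower number from compound 3 to compound 4 (0.24 log units; within the scatter). Compound 4 is therefore estimated at 12 nM, with a range from 4 nM to 40 nM.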

Compound 4, half-maximal inhibitory concentration: 28 nM
The estimate for compound 4 lay 2.3-fold (0.37 log units) below the measured number; the range from low to high includes it.
By their numbers in this assay, from the lowest: compound 2; then compounds 3, 4 and 1 (each within the scatter of the next).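

In this assay the 4-methyl-1H-imidazol-1-yl group does not repeat what phenyl did in place of cyclohexyl: the readings a 1.3-fold higher number from compound 3 to compound 4 (0.12 log units; within the scatter) and a 1.3-fold lower number from compound 1 to compound 4 (0.12 log units; within the scatter) both stay within the scatter, so compound 4 sits level with compounds 1 and 3. Only the reading a 2.8-fold higher number from compound 2 to compound 4 (0.45 log units; beyond the scatter) clears the scatter, and it is modest, so an aromatic ring on this carbon does not by itself go with the lowest number; compound 2 shows that link and compound 4 goes against it. No measurement at hand accounts for this difference between the two aromatic rings.

Open, from the compounds shown here alone, is whether plain imidazol-1-yl, without the methyl, reads differently from compound 4. Also open, going by these compounds, is whether an anilino group or a directly attached phenyl ring falls with compound 2 or with compound 4.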